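A cyclopentyl ether swapped for a bromopyrimidinyl ether

A few compounds are considered here, and "the series" means these few. Any claim that something is new, unique, unknown or untested is made for them only; others in the source may bear on it.

Compound 1, `CC#CC(CC(=O)O)c1ccc(OC2CCCC2)cc1`, gives 124 nM in a functional assay on CHO cells for agonist activity at Free fatty acid receptor 1 (Mus musculus), read by FLIPR and calcium flux; a higher number here means that more compound is needed for the effect, a lower number that less compound is needed.
Compound 2, `CC#CC(c1ccc(OCc2ccccc2)cc1)C1OC(=O)NC1=O`, gives 3710 nM in this assay.

Compound 1 shows the lower of the two numbers, and compound 2 sits well beyond the scatter above it. Compound 3, `CC#CC(CC(=O)O)c1ccc(Oc2ncc(Br)cn2)cc1`, differs from compound 1 by 5-bromopyrimidin-2-yl in place of cyclopentyl on an oxygen on an aromatic ring. Among the measured compounds shown here, no measured pair shows this particular exchange, so the size of the step is open; a modest shift in this assay is expected, if any, most likely toward a somewhat higher number. Compound 3 is therefore estimated at 200 nM, within 60 nM to 700 nM, a step of a 1.6-fold higher number from compound 1 to compound 3 (0.21 log units; within the scatter).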

Compound 3, half-maximal effective concentration: 1480 nM
Estimate against measurement, compound 3: 7.4-fold (0.87 log units) below, and the stated range ends below it.
By their numbers in this assay, from the lowest: compound 1; then compound 3; then compound 2.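

On an oxygen on an aromatic ring, the exchange of cyclopentyl for 5-bromopyrimidin-2-yl in this assay brings a 12-fold higher number from compound 1 to compound 3 (1.08 log units; beyond the scatter), so this position is sensitive to what it carries, with the rest of compound 1 unchanged. Of the two groups, cyclopentyl goes with the lower number. No measured property of either group is available to account for the step.

Open, going by these compounds, is whether phenyl or unsubstituted pyrimidin-2-yl on that oxygen would stand nearer compound 1 or compound 3, and so whether the bromine, the ring nitrogens or the aromatic ring itself carries the step.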